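Working notes: the iodo step in a halogen series

The compounds below may be only part of what the source reports. "The series", "measured", "known", "first", "only" and "open" are said of these compounds alone.

- compound 1 `COc1ccc(-c2nc3cc(F)ccc3s2)cc1F` gives 870 nM
- compound 2 `COc1ccc(-c2nc3cc(F)ccc3s2)cc1Cl` gives 760 nM
- compound 3 `COc1ccc(-c2nc3cc(F)ccc3s2)cc1Br` gives 850 nM

In a functional assay on MCF7 cells (Homo sapiens) for antiproliferative activity (a lower number here means a stronger inhibitor of growth, a higher number a weaker inhibitor of growth), compound 3 gives 850 nM and stands level with the other two measured compounds, within the scatter of both. The measured steps that reach it are a 1.0-fold lower number from compound 1 to compound 3 (0.01 log units; within the scatter) and a 1.1-fold higher number from compound 2 to compound 3 (0.05 log units; within the scatter) at the same carbon. Alongside them, a 1.1-fold lower number from compound 1 to compound 2 (0.06 log units; within the scatter) completes the set, and the three values do not separate.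

Compound 4 `COc1ccc(-c2nc3cc(F)ccc3s2)cc1I` has not been measured. It differs from compound 3 by iodo in place of bromo on an aromatic carbon as a single change: iodo in place of bromo on an aromatic carbon, ortho to a methoxy group. All three measured steps are exchanges of one halogen for another at this carbon, so they are the ones that bear on the change. Among the measured compounds shown here, no iodo compound has been measured, so the expectation rests on these three compounds alone. Going by a 1.1-fold higher number from compound 2 to compound 3 (0.05 log units; within the scatter) no step beyond the scatter is expected in this assay in either direction. The estimated move is a 1.1-fold lower number from compound 3 to compound 4 (0.03 log units; within the scatter) on this reading. For compound 4 the estimated value is 800 nM with an expected range from 450 nM to 1400 nM in this read-out.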

Compound 4, concentration for 50% growth inhibition: 820 nM
For compound 4 the middle estimate is 1.0-fold (0.01 log units) below the measured one; measured number inside the range.
By their numbers in this assay, from the lowest: compounds 2, 4, 3 and 1 (each within the scatter of the next).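

In this assay, the iodo compound joins the halogen series at this aromatic carbon without separating from the others: a 1.0-fold lower number from compound 3 to compound 4 (0.02 log units; within the scatter), a 1.1-fold higher number from compound 2 to compound 4 (0.03 log units; within the scatter) and a 1.1-fold lower number from compound 1 to compound 4 (0.03 log units; within the scatter). The level picture given by fluoro, chloro and bromo therefore extends to a fourth halogen, and no step among these four compounds lies beyond the scatter, so this read-out does not distinguish any of the four halogens at this carbon. Nothing available here accounts for the level values.

Going by these compounds, whether this carbon stays as level for a group other than a halogen, such as an amine, a carboxylic acid or a nitrile, remains open. On these data alone, the methoxy group and the fluoro on the shared core are also the same in all four compounds, so it is equally open whether the halogen exchanges would stay level with a longer alkoxy chain in place of the methoxy group.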